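The source may report more compounds than this note shows. Statements on the series, on what has been measured and on what is new or still open speak of the compounds shown alone.

Going by the values given here, compound 1, with the structure `COc1ccc(-c2nsc3c2NC(=O)CC3c2cccc(Cl)c2)cc1`, is the only member of this small set for which a number exists: in a functional assay on NCI60 cells (Homo sapiens) for antiproliferative activity, read by sulforhodamine B assay, with a stated time of 48 h (on this read-out higher numbers stand for weaker inhibition of growth and lower numbers for stronger inhibition of growth), compound 1 gives 1740 nM. Two close relatives, compound 2 with the structure `O=C1CC(c2cccc(Cl)c2)c2snc(-c3cccc(F)c3)c2N1` and compound 3 with the structure `O=C1CC(c2ccc(F)cc2)c2snc(-c3cccc(F)c3)c2N1`, carry no number in this assay: for compound 2 the entry in this assay reads "not determined" (no result reported), and for compound 3 the entry in this assay reads "not determined" (no result reported). Compound 1 therefore cannot be placed above or below any neighbour; it simply stands alone as the one fixed point.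

The untested compound 4, with the structure `COc1ccc(-c2nsc3c2NC(=O)CC3c2ccsc2)cc1`, differs from compound 1 in a single place: thiophen-3-yl in place of 3-chlorophenyl on a saturated ring carbon. The rest of the shared core, including the amide-containing ring and the methoxyphenyl group, is left untouched.

Among the compounds with values here, no step between two measured compounds is available to show how this assay responds to a change at that saturated ring carbon. Within the data shown here, with only one number to lean on, the step from compound 1 to compound 4 is expected to be small, either within the usual scatter or a modest loss of potency, and the estimate a 1.5-fold higher number from compound 1 to compound 4 (0.17 log units; within the scatter) reflects that. Compound 4 is therefore expected to give about 2600 nM in this assay, with a range from 800 nM to 8500 nM.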

Compound 4, concentration for 50% growth inhibition: 302 nM
The estimate for compound 4 lay 8.6-fold (0.93 log units) above the measured number; measured number below the stated range.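

The saturated ring carbon is not a silent position: in this assay, replacing 3-chlorophenyl with thiophen-3-yl gives a clear gain in growth inhibition (a 5.8-fold lower number from compound 1 to compound 4 (0.76 log units; beyond the scatter)). Compound 1 alone could not show this, and the step also shows that a six-membered aromatic ring of carbon with a chlorine on it is not required at this carbon for activity, since a five-membered aromatic ring with 1 hetero atom does better here. Why the number falls cannot be said, as nothing shown explains the step in terms of any measured property.

This single step changes the ring size, the chlorine and the hetero atom all at once, so the compounds shown cannot separate these contributions, and plain phenyl, thiophen-2-yl or furan-3-yl at this carbon would be the groups to tell them apart. Going by these compounds alone, the gain is also seen only with the methoxyphenyl group in place on the core, so whether it carries over to the 3-fluorophenyl partner of compound 2 and compound 3, or to a group such as a pyridine ring or an amine at the saturated carbon, remains open.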